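The source may hold more compounds than are shown below. What is called first, only, known or untested is meant among the compounds shown, and "the series" means these compounds.

Measured compounds so far:
- compound 1 `CN1CCN(CCCCCn2c3c(c4ccccc42)C(=O)c2c[n+]([O-])c4ccccc4c2C3=O)CC1`: 830 nM
- compound 2 `O=C1c2c[n+]([O-])c3ccccc3c2C(=O)c2c1c1ccccc1n2Cc1cn([C@H]2C[C@H](O)[C@@H](CO)O2)nn1`: 620 nM
- compound 3 `O=C1c2c[n+]([O-])c3ccccc3c2C(=O)c2[nH]c3ccccc3c21`: 1380 nM

All three numbers come from a functional assay on SH-SY5Y cells (Homo sapiens) for cytotoxicity, read by MTT assay, with a stated time of 72 h; on this read-out lower numbers stand for stronger inhibition and higher numbers for weaker inhibition. Among the measured compounds shown here, compound 2 stands within the scatter of compound 1, and its gap to compound 3 lies beyond the scatter; no single-place step between compound 2 and compound 3 is recorded, so the two values are simply noted side by side. For the measured compounds named here, the one recorded single-place step is a 1.7-fold higher number from compound 1 to compound 3 (0.22 log units; within the scatter), which shows that stripping the whole chain from the aromatic nitrogen of the shared core moves the number very little.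

Compound 4 `O=C1c2c[n+]([O-])c3ccccc3c2C(=O)c2c1c1ccccc1n2Cc1cn(CC(O)CO)nn1` is the next member. Relative to compound 2 the change is 2,3-dihydroxypropyl in place of 4-hydroxy-5-(hydroxymethyl)oxolan-2-yl on an aromatic nitrogen. Going by the values given here, this change sits on the triazole nitrogen, far from the shared core, and the only measured step bears on it indirectly: if removing an entire chain from the core nitrogen stays within the scatter, a swap of one hydroxylated group for another at the remote end of the substituent is expected to stay within the scatter as well, in either direction. For compound 4 in this assay the expected value is therefore 750 nM, with a range from 350 nM to 1600 nM. The step this implies, a 1.2-fold higher number from compound 2 to compound 4 (0.08 log units; within the scatter), is expected to be small, with no clear direction.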

Compound 4, half-maximal inhibitory concentration: > 1000 nM
Compound 4: no number, only a limit; the forecaster's own chance of this, stated with the estimate: 5%; middle value at least 1.3-fold (0.12 log units) from the limit.
By their numbers in this assay, from the lowest: compounds 2, 1 and 3 (each within the scatter of the next, the first and the last beyond it).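

In this assay the result for compound 4 is a limit and not a number: the limit of > 1000 nM in this assay, at which 1 of the 4 values shown sits.

On the aromatic nitrogen of the five-membered aromatic ring with 3 nitrogen, the ring-free 2,3-dihydroxypropyl in place of 4-hydroxy-5-(hydroxymethyl)oxolan-2-yl gives an at least 1.6-fold higher number from compound 2 to compound 4 (0.20 log units; that floor lies within the scatter), the first step at this position among the compounds shown, and it sets only a floor. The swap of 4-(4-methylpiperazin-1-yl)butyl for 1-(2,3-dihydroxypropyl)-1H-1,2,3-triazol-4-yl on the saturated chain carbon bound to the aromatic nitrogen gives an at least 1.2-fold higher number from compound 1 to compound 4 (0.08 log units; that floor lies within the scatter), again only a floor, while the remaining step, from hydrogen on that aromatic nitrogen, cannot be read.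

From the compounds shown here alone, whether the true size of either step lies beyond the scatter stays open, and with it whether the change at this position matters at all in this assay. Also open, going by these compounds, is how a carboxylic acid, a primary amine or a longer hydroxyalkyl chain on the same aromatic nitrogen would read, and whether the five-membered non-aromatic ring or its 3 defined stereocentres have any bearing on the result.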